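A few compounds are considered here, and "the series" means these few. Any claim that something is new, unique, unknown or untested is made for them only; others in the source may bear on it.

Measured compounds in a functional assay on A549 cells (Homo sapiens) for inhibition, with a stated time of 72 h; on this read-out higher numbers stand for weaker inhibition and lower numbers for stronger inhibition:
compound 1 `COc1ccc(NC(=O)Nc2nc(Sc3c[nH]c4ccccc34)cc(N3CCCCC3)n2)cc1` gives 13500 nM
compound 2 `COc1ccc(NC(=O)Nc2nc(Sc3c[nH]c4ccccc34)cc(N3CCN(c4ccccn4)CC3)n2)cc1` gives only a limit, > 50000 nM
compound 3 `O=C(Nc1ccccc1)Nc1nc(Nc2ccccc2)cc(Sc2c[nH]c3ccccc23)n1` gives only a limit, > 50000 nM

Compound 2 stands at the upper limit of this assay; its entry is a limit, not a number. Of the three values shown, two sit there (the limit of > 50000 nM in this assay, at which 2 of the 3 values shown sit), so compound 2 cannot be ranked against compound 3, and only its distance from compound 1 is resolved: an at least 3.7-fold higher number from compound 1 to compound 2 (0.56 log units; beyond the scatter), a step toward weaker inhibition that is at least modest and beyond the scatter.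

The change to compound 4 `COc1ccc(NC(=O)Nc2nc(Nc3cc(OC)cc(OC)c3)cc(Sc3c[nH]c4ccccc34)n2)cc1` is (3,5-dimethoxyphenyl)amino in place of 4-(pyridin-2-yl)piperazin-1-yl on an aromatic carbon. Among the measured compounds shown here, no measured step with a single change covers this swap. For the measured compounds named here, the only step known, an at least 3.7-fold higher number from compound 1 to compound 2 (0.56 log units; beyond the scatter), runs into the limit and so gives no direction for a further change at that place. Compound 3, which carries a phenylamino group at the same place of the shared core, also returns only a limit in this assay, though it differs from compound 4 in more than one place.

On this basis the step of an at least 1.1-fold lower number from compound 2 to compound 4 (0.04 log units; that floor lies within the scatter) is expected to be none that can be resolved, with a limit the most likely outcome. Compound 4 is therefore estimated at 45000 nM, within 12000 nM to 150000 nM.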

Compound 4, half-maximal inhibitory concentration: > 50000 nM
Compound 4: a limit, no number; the forecaster's own chance of this, stated with the estimate: 65%; at least 1.1-fold (0.04 log units) between middle value and limit.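

On this aromatic carbon of the shared core, the loss is no longer tied to 4-(pyridin-2-yl)piperazin-1-yl: in this assay, (3,5-dimethoxyphenyl)amino in place of piperidin-1-yl gives an at least 3.7-fold higher number from compound 1 to compound 4 (0.56 log units; beyond the scatter). Among the compounds shown here, two quite different groups, one with a non-aromatic ring and a pyridine-type ring and the other with one ring of carbon only and a hydrogen-bond donor, thus both step away from piperidin-1-yl in the same direction, with no compound going against this among those that differ at this place alone. Compound 4 returns a limit rather than a number, the step between compound 2 and compound 4 cannot be read, and the two groups stay unranked, with the values crowding at one end of the read-out: the limit of > 50000 nM in this assay, at which 3 of the 4 values shown sit.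

Piperidin-1-yl remains the only group at this place with a measured number, so it is open whether that number is special to this group or is shared by close amines such as pyrrolidin-1-yl or morpholin-4-yl. Also open, going by these compounds, is whether a simple dimethylamino group would keep a readable value, which would show how much of the piperidine ring is needed.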